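Removing a hydroxy from a terpenoid cytotoxin scaffold

The source may hold more compounds than are shown below. What is called first, only, known or untested is meant among the compounds shown, and "the series" means these compounds.

Measured compounds:
compound 1, `C=C1C(=O)[C@H]2C[C@]1(O)CC1=C2[C@]2(C)CCCC(C)(C)[C@H]2CC1`, 3400 nM
compound 2, `C[C@@H]1C(=O)[C@H]2C[C@]1(O)CC1=C2[C@]2(C)CCC[C@](C)(CO)[C@H]2CC1`, > 50000 nM

In a functional assay on MDA-MB-231 cells (Homo sapiens) for cytotoxicity, read by MTT assay, with a stated time of 24 h (a higher number here means a weaker inhibitor, a lower number a stronger inhibitor), compound 1 gives 3400 nM. For compound 2 the result is only a limit of the assay, > 50000 nM, so no number is known for it; (the limit of > 50000 nM in this assay, at which 1 of the 2 values shown sits). Within the data shown here, compound 2 thus stands at the weak end of what has been recorded, while compound 1 is the only compound with a measured value.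

Compound 3, `C[C@@H]1C(=O)[C@H]2C[C@]1(O)CC1=C2[C@]2(C)CCCC(C)(C)[C@H]2CC1`, is still to be measured in this assay . It differs from compound 2 by hydrogen in place of hydroxy on a saturated chain carbon bound to a saturated ring carbon.

Because compound 2 sits at > 50000 nM, only a step toward stronger inhibition, or none beyond the scatter, can be expected from compound 2 to compound 3. The estimate for compound 3 is 25000 nM, within a range from 7000 nM to 50000 nM, which means an expected step of an at least 2.0-fold lower number from compound 2 to compound 3 (0.30 log units; that floor lies within the scatter).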

Compound 3, half-maximal inhibitory concentration: > 50000 nM
Compound 3 gave a limit, no number; the forecaster's own chance of this, stated with the estimate: 40%; at least 2.0-fold (0.30 log units) between middle value and limit.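

Compound 3 gives only a limit, > 50000 nM, in this assay. Compound 2 also gives a limit, so no step can be read from compound 2 to compound 3. The compounds shown leave open whether hydrogen in place of hydroxy changes the cytotoxicity at all.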